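A few compounds are considered here, and "the series" means these few. Any claim that something is new, unique, unknown or untested is made for them only; others in the source may bear on it.

In an assay on isolated protein for inhibition of ubiquitin carboxyl-terminal hydrolase 7 (Homo sapiens), read by fluorescence, with stated times of 30 min and 1 h (a higher number here means a weaker inhibitor, a lower number a stronger inhibitor), three compounds have so far been measured. Compound 1 `Nc1cc(-c2cc(Cl)cc3c2OC(C(=O)N2CCNCC2)C3)ccn1` gives 5600 nM. Compound 2 `Cc1cc(Cl)cc(-c2ccnc3cc(CN4C(=O)C5C(C4=O)C5(C)C)sc23)c1OC1CCCNC1` gives 2.4 nM, and compound 3 `Cn1nc2c(c1[C@H]1Cc3cc(Cl)cc(-c4ccnc5cc(CN6C(=O)CCC6=O)sc45)c3O1)CNCC2` gives 1.1 nM. Compound 2 therefore stands second highest of the three numbers: its nearest neighbour is compound 3, whose lower number lies beyond the scatter, and its furthest is compound 1, whose far higher number lies well beyond the scatter.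

Compound 4 `Cc1cc(Cl)cc(-c2ccnc3cc(CN4C(=O)C5C(C4=O)C5(C)C)sc23)c1CC1CCCNC1` has not yet been measured. It differs from compound 2 in a single place: (piperidin-3-yl)methyl in place of (piperidin-3-yl)oxy on an aromatic carbon. Within the data shown here, no measured pair shows this exchange, so the expectation rests on compound 2 alone, whose value of 2.4 nM in this assay is the anchor. The step of a 1.7-fold higher number from compound 2 to compound 4 (0.22 log units; within the scatter) is expected to be small, if anything towards a weaker inhibitor, and most likely within the scatter. Compound 4 is therefore expected to give about 4 nM in this assay, with a range from 1.5 nM to 12 nM.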

Compound 4, half-maximal inhibitory concentration: 1.3 nM
Estimate against measurement, compound 4: 3.1-fold (0.49 log units) above; measured number below the stated range.
By their numbers in this assay, from the lowest: compounds 3, 4 and 2 (each within the scatter of the next, the first and the last beyond it); then compound 1.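

In this assay, putting (piperidin-3-yl)methyl in place of (piperidin-3-yl)oxy on this aromatic carbon, ortho to a large group and to a methyl group, gives a 1.8-fold lower number from compound 2 to compound 4 (0.27 log units; within the scatter) and so cannot be told apart from repeat scatter. In this pair, the oxygen attached to the aromatic carbon is therefore not needed to keep the value, even though the count of hydrogen-bond acceptors in the group goes from 2 to 1. No measurement here speaks to why the exchange is tolerated.

This single pair leaves open whether the same exchange would be tolerated on another core, such as that of compound 3. It also leaves open whether an amine nitrogen in the same place, or a longer chain between the piperidine ring and the aromatic carbon, would keep the value.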